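This account rests on a few compounds, and the source may have more. Where it says the series, first, only, none or still open, it means among the compounds named here.

Measured so far:
Compound 1, `Cc1ccc(S(=O)(=O)N2CC(c3nc(-c4cccc(Cl)c4)no3)C2)cc1`, in an assay on HEK293 cells for negative allosteric modulation of metabotropic glutamate receptor 5 (Homo sapiens), read by FLIPR (on this read-out higher numbers stand for weaker inhibition and lower numbers for stronger inhibition), gives 920 nM.
Compound 2, `O=S(=O)(c1ccc(F)cc1)N1CC(c2nc(-c3cccc(Cl)c3)no2)C1`, in this assay gives 130 nM.

Going by the values given here, compound 2 holds the lowest number of the two, and its only neighbour is compound 1, with a 7.1-fold lower number from compound 1 to compound 2 (0.85 log units; beyond the scatter), a step that lies beyond the scatter. Compound 3, `Cc1cccc(-c2noc(C3CN(S(=O)(=O)c4ccc(F)cc4)C3)n2)c1`, has not yet been measured in this assay. It differs from compound 2 by methyl in place of chloro on an aromatic carbon, so the change sits on the 3-chlorophenyl side of the shared core, not on the sulfonyl-bearing ring where the measured step took place. That measured step, from compound 1 to compound 2, was modest in size and concerned a different ring and a different pair of groups, so it gives no direct guide to the present change; it shows only that a single small substituent swap on this core can shift the number by more than the scatter. A step of similar or smaller size is therefore expected here, with the direction uncertain and a mild weakening judged somewhat more likely, that is a 1.9-fold higher number from compound 2 to compound 3 (0.28 log units; within the scatter). For compound 3 the estimate in this assay is 250 nM, within a range from 80 nM to 800 nM.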

Compound 3, half-maximal inhibitory concentration: 950 nM
For compound 3 the middle estimate is 3.8-fold (0.58 log units) below the measured one; measured number outside the range, above it.
By their numbers in this assay, from the lowest: compound 2; then compounds 1 and 3 (each within the scatter of the next).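

In this assay the 3-chlorophenyl side of the shared core proves sensitive: going to 3-methylphenyl produces a 7.3-fold higher number from compound 2 to compound 3 (0.86 log units; beyond the scatter) even though one heavy atom simply replaces another, and neither group adds a ring, a charge, or a hydrogen-bond donor or acceptor. The only earlier step, a 7.1-fold lower number from compound 1 to compound 2 (0.85 log units; beyond the scatter) on a different part of the molecule, now has a counterpart running the same way, since in both pairs the compound with methyl holds the higher number and the one with chloro or fluoro holds the lower; no compound shown goes against this, but two steps are a very thin basis for a pattern. Nothing available here accounts for the size of this step or explains why methyl and chloro read so differently at this place.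

As far as these compounds go, what other groups would do at this place remains open, for example a methoxy group, a nitrile or an amine. Also open, from the compounds shown here alone, is whether the chloro keeps its advantage over methyl at other places on the same ring or with other groups on the sulfonyl side.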